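Methoxy for Carbamoyl at the Cytotoxicity Limit

The source may report more compounds than this note shows. Statements on the series, on what has been measured and on what is new or still open speak of the compounds shown alone.

In an ADME assay on Raji cells (Homo sapiens) for cytotoxicity, with a stated time of 72 h (a higher number here means that more compound is needed for the effect, a lower number that less compound is needed), compound 1 (`Cc1cc(NC(=O)Nc2ccc(C)c(Cl)c2)c2ccccc2n1`) gives > 25000 nM as a limit of the assay and not a number. Compound 2 (`Cc1cc(NC(=O)Nc2cccc(C(N)=O)c2)c2ccccc2n1`) likewise gives > 25000 nM as a limit. Where compound 2 stands is therefore known only as a limit (the limit of > 25000 nM in this assay, at which 2 of the 2 values shown sit). Compound 3 (`COc1cccc(NC(=O)Nc2cc(C)nc3ccccc23)c1`) carries methoxy in place of carbamoyl on an aromatic carbon, meta to a large group (methoxy in place of carbamoyl on an aromatic carbon). Going by the values given here, no measured step exists between these compounds, so the expectation in this assay rests on compound 2 with its limit of > 25000 nM and little else. No change beyond the scatter is expected, and another limit is the likeliest report. The step is expected to stay within the scatter (a number no higher from compound 2 to compound 3 (the limit leaves the size open)). The estimate for compound 3 is 25000 nM (expected range 12000 nM to 50000 nM).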

Compound 3, half-maximal effective concentration: > 25000 nM
Compound 3: no number, only a limit (the forecaster's own chance of this, stated with the estimate: 85%); the middle value lies on the limit itself.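

Going by these compounds alone, compound 2 and compound 3 both give only a limit in this assay, so no step between them can be read. The compounds shown leave open how much of any of them is needed for the effect, and whether exchanging carbamoyl for methoxy changes that amount.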